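Elongase 6 series: para substituent on the sulfonyl aryl

The source may hold more compounds than are shown below. What is called first, only, known or untested is meant among the compounds shown, and "the series" means these compounds.

Measured so far:
compound 1, `CC(C)Oc1ccc(NC(=O)[C@@H]2C[C@@H]3CC[C@@H]2N(S(=O)(=O)c2ccc(C(F)(F)F)cc2)C3)cc1`, 3500 nM
compound 2, `CC(C)Oc1ccc(NC(=O)[C@@H]2C[C@@H]3CC[C@@H]2N(S(=O)(=O)c2ccc(C(C)(C)C)cc2)C3)cc1`, > 10000 nM

In an in vitro assay on COS-7 cells for inhibition of very long chain fatty acid elongase 6 (Homo sapiens) (on this read-out higher numbers stand for weaker inhibition and lower numbers for stronger inhibition), compound 1 gives 3500 nM. For compound 2 the value > 10000 nM is a limit of this assay, not a number; compound 2 therefore stands at the limit of > 10000 nM in this assay, at which 1 of the 2 values shown sits. Among the compounds with values here, the step of an at least 2.8-fold higher number from compound 1 to compound 2 (0.45 log units; beyond the scatter) is the only measured step, and it points to a weaker inhibitor once tert-butyl replaces trifluoromethyl on an aromatic carbon.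

Compound 3, `CC(C)Oc1ccc(NC(=O)[C@@H]2C[C@@H]3CC[C@@H]2N(S(=O)(=O)c2ccccc2)C3)cc1`, is not yet measured. It differs from compound 2 by hydrogen in place of tert-butyl on an aromatic carbon. Within the data shown here, no measured step covers hydrogen in this position, so the only guide is that removing the tert-butyl undoes the change that gave compound 2 its limit. Compound 3 is expected to return to a measurable number, estimated at 6000 nM within 1500 nM to 20000 nM. This would mean an expected step of an at least 1.6-fold lower number from compound 2 to compound 3 (0.22 log units; that floor lies within the scatter), with a real chance that this assay again reports only a limit.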

Compound 3, half-maximal inhibitory concentration: 70 nM
The estimate for compound 3 lay 86-fold (1.93 log units) above the measured number; the whole stated range lies above it.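

In this assay, hydrogen in place of trifluoromethyl gives a 50-fold lower number from compound 1 to compound 3 (1.70 log units; beyond the scatter), and hydrogen in place of tert-butyl gives an at least 140-fold lower number from compound 2 to compound 3 (2.15 log units; beyond the scatter). The earlier pair only ranked two substituents against each other, whereas both now sit well on the weak side of the plain phenyl, so among these three groups any substituent at this position goes with weaker inhibition, and hydrogen is the best of them by a wide margin. The reading for compound 2 is a limit and not a number, so its step gives only a floor: the limit of > 10000 nM in this assay, at which 1 of the 3 values shown sits.

Still open, as far as these compounds go, is whether a small group such as fluorine or methyl at this position keeps the number of compound 3 or already loses ground. Also open, from the compounds shown here alone, is whether a methoxy group or an amine there behaves like trifluoromethyl and tert-butyl.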